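A few compounds are considered here, and "the series" means these few. Any claim that something is new, unique, unknown or untested is made for them only; others in the source may bear on it.

Measured so far in a functional assay on HT-29 cells (Homo sapiens) for cytotoxicity, read by MTT assay, with a stated time of 72 h; on this read-out lower numbers stand for stronger inhibition and higher numbers for weaker inhibition:
compound 1 `CN1[C@@H]2c3[nH]c4ccccc4c3C[C@H]1[C@H](C#N)N1[C@@H](CN3C(=O)c4ccccc4C3=O)c3[nH]c4ccccc4c3C[C@@H]21`: 80 nM
compound 2 `CN1[C@@H]2c3[nH]c4ccccc4c3C[C@H]1[C@H](C#N)N1[C@@H](CNC(=O)c3cccc(C(F)(F)F)c3)c3[nH]c4ccccc4c3C[C@@H]21`: 140 nM
compound 3 `CN1[C@@H]2c3[nH]c4ccccc4c3C[C@H]1[C@H](C#N)N1[C@@H](CNC(=O)c3cccc4c3CCCC4)c3[nH]c4ccccc4c3C[C@@H]21`: 3340 nM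

Compound 3 stands at the highest number of the three. Within the data shown here, the one single-point step recorded is a 24-fold higher number from compound 2 to compound 3 (1.38 log units; beyond the scatter), and the gap from compound 1 to compound 3 is wider still, so the amide substituent at this position governs much of the spread seen so far.

Compound 4 `CN1[C@@H]2c3[nH]c4ccccc4c3C[C@H]1[C@H](C#N)N1[C@@H](CNC(=O)c3cc4ccccc4o3)c3[nH]c4ccccc4c3C[C@@H]21` differs from compound 3 in one place: 1-benzofuran-2-yl in place of 1,2,3,4-tetrahydronaphthalen-5-yl on a carbonyl carbon. Among the measured compounds shown here, the only measured step that bears on this site is a 24-fold higher number from compound 2 to compound 3 (1.38 log units; beyond the scatter), which shows that exchanging the aryl group on the carbonyl carbon moves the read-out far beyond the scatter. The group leaving carries a six-membered non-aromatic ring; the group entering is aromatic in both rings and brings one hydrogen-bond acceptor, which in counted features places compound 4 nearer to compound 2 than to compound 3. A lower number than compound 3 is therefore expected, with an estimated step of an 8.4-fold lower number from compound 3 to compound 4 (0.92 log units; beyond the scatter). The estimate for compound 4 is 400 nM, with a range from 100 nM to 2000 nM.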

Compound 4, half-maximal inhibitory concentration: 850 nM
Compound 4: middle estimate off by 2.1-fold (0.33 log units), on the low side, and the stated range covers the measured number.
By their numbers in this assay, from the lowest: compounds 1 and 2 (each within the scatter of the next); then compound 4; then compound 3.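

In this assay, the step of a 3.9-fold lower number from compound 3 to compound 4 (0.59 log units; beyond the scatter) shows that 1-benzofuran-2-yl recovers only part of what 1,2,3,4-tetrahydronaphthalen-5-yl loses on the carbonyl carbon, while the step of a 6.1-fold higher number from compound 2 to compound 4 (0.78 log units; beyond the scatter) keeps it clearly short of 3-(trifluoromethyl)phenyl, so the three aryl groups on this carbonyl carbon give three separate levels. The wider change, an 11-fold higher number from compound 1 to compound 4 (1.03 log units; beyond the scatter), places compound 4 further still from compound 1, whose group carries a five-membered non-aromatic ring in place of the five-membered aromatic ring. Nothing measured on hand accounts for this order of groups.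

Open, on these data alone, is whether the ring oxygen of 1-benzofuran-2-yl matters, which a 1-benzothiophen-2-yl on the carbonyl carbon would address. Also open, as far as these compounds go, is how a plain phenyl or a phenyl bearing an amine would fall in this order.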